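The source may hold more compounds than are shown below. What is called first, only, known or untested is meant among the compounds shown, and "the series" means these compounds.

Measured so far in a toxicity assay on Vero C1008 cells (Chlorocebus sabaeus) for cytotoxicity, read by neutral red uptake, with a stated time of 5 days; on this read-out lower numbers stand for higher toxicity in this test and higher numbers for lower toxicity in this test:

Compound 1 `C[C@H](NC(=O)C(c1cccnc1)N(C(=O)c1ccco1)c1ccc(C2CCCCC2)cc1)c1ccccc1`: 9610 nM
Compound 2 `C[C@H](NC(=O)C(c1cccnc1)N(C(=O)c1ccco1)c1ccc(-c2ccco2)cc1)c1ccccc1`: 56400 nM

Compound 2 stands at the highest of the two numbers in this assay, and its nearest neighbour is compound 1, with a 5.9-fold higher number from compound 1 to compound 2 (0.77 log units; beyond the scatter) separating them. Going by the values given here, that single step is the only measured change at the aromatic carbon in question, and it tells what happens when the cyclohexyl group is exchanged for an aromatic five-membered ring with one hetero atom.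

Compound 3 `C[C@H](NC(=O)C(c1cccnc1)N(C(=O)c1ccco1)c1ccc(-c2cccs2)cc1)c1ccccc1` has not yet been measured. It differs from compound 2 by thiophen-2-yl in place of furan-2-yl on an aromatic carbon. Among the compounds with values here, no measured pair covers a furan-2-yl to thiophen-2-yl exchange, so the one step on record bears on it only indirectly: it shows that the number at this position can move by a modest amount when the group is changed, but the present change keeps the same ring size, the same hetero atom count and the same acceptor count.

For compound 3 the number in this assay is therefore expected to stay close to that of compound 2, with no step beyond the scatter; the estimated step is a 1.3-fold lower number from compound 2 to compound 3 (0.10 log units; within the scatter). The expected value for compound 3 is 45000 nM, within a range from 18000 nM to 115000 nM.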

Compound 3, half-maximal cytotoxic concentration: 89600 nM
Compound 3: middle estimate off by 2.0-fold (0.30 log units), on the low side; low and high end bracket the measured number.
By their numbers in this assay, from the lowest: compound 1; then compounds 2 and 3 (each within the scatter of the next).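

In this assay, thiophen-2-yl in place of furan-2-yl at this position, para to a large group, gives a 1.6-fold higher number from compound 2 to compound 3 (0.20 log units; within the scatter), so the two five-membered aromatic rings with 1 hetero atom, one holding oxygen and one sulfur, cannot be told apart in this test. The separation from the cyclohexyl compound now rests on two aromatic groups rather than one, with a 9.3-fold higher number from compound 1 to compound 3 (0.97 log units; beyond the scatter) alongside a 5.9-fold higher number from compound 1 to compound 2 (0.77 log units; beyond the scatter); among these three compounds, none goes against the cyclohexyl compound having the lowest number, which here stands for the highest toxicity in this test. Nothing available gives a reason for either the small or the larger steps.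

Going by these compounds, with a single saturated group in the set, it remains open whether the gap belongs to cyclohexyl alone or extends to other saturated rings, such as a cyclopentyl or a tetrahydropyranyl group. Also open, on these data alone, is how this position responds to a six-membered aromatic group such as phenyl, or to groups of a different kind, such as an amine or a carboxylic acid.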